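The source may hold more compounds than are shown below. What is called first, only, known or untested is meant among the compounds shown, and "the series" means these compounds.

Working notes on the series. Compound 1 `CN1CCN(c2ccc(C3=NN(S(=O)(=O)c4ccc(F)cc4)C(c4ccc(N(C)C)cc4)C3)cc2)CC1` gives 95.7% in a functional assay on NCI-H1975 cells (Homo sapiens) for inhibition, read by sulforhodamine B assay, tested at 10 uM; a lower number here means less inhibition, a higher number more inhibition at the concentration tested (going by the name of the read-out). Compound 2 `CN1CCN(c2ccc(C3=NN(S(=O)(=O)c4ccc(Br)cc4)C(c4ccc(N(C)C)cc4)C3)cc2)CC1` gives 70.8% in this assay. The two differ in one place, (bromo in place of fluoro on an aromatic carbon), and that change made a step of a number 24.9 percentage points lower from compound 1 to compound 2 (beyond the scatter).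

Compound 3 `CN(C)c1ccc(C2CC(c3ccc(-n4cncn4)cc3)=NN2S(=O)(=O)c2ccc(F)cc2)cc1` gives -0.5% in this assay, the lowest of the three numbers; the nearest is compound 2, and the furthest is compound 1, both beyond the scatter. The core of compound 3 differs from the core of compound 1 by 1H-1,2,4-triazol-1-yl in place of 4-methylpiperazin-1-yl on an aromatic carbon, and that difference made a step of a number 96.2 percentage points lower from compound 1 to compound 3 (beyond the scatter), essentially removing inhibition at the tested concentration.

Compound 4 `CN(C)c1ccc(C2CC(c3ccc(-n4cncn4)cc3)=NN2S(=O)(=O)c2ccc(Br)cc2)cc1` has not yet been measured in this assay. It differs from compound 3 by bromo in place of fluoro on an aromatic carbon, the same change as from compound 1 to compound 2, at a place described in identical words. That earlier change gave a step of a number 24.9 percentage points lower from compound 1 to compound 2 (beyond the scatter), a modest lowering from a high starting level. Compound 3, however, already stands at -0.5%, so there is little room for a further lowering of comparable size, and nothing among the three measured compounds shows this change raising inhibition. The step from compound 3 to compound 4 is expected to be a number 1.5 percentage points higher from compound 3 to compound 4 (within the scatter), essentially flat and within the scatter. Compound 4 is therefore estimated at 1% in this assay. For compound 4 the expected range runs from -10% to 14%.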

Compound 4, a percentage reported as inhibition, at one concentration (the size of the read-out at that concentration, not a potency): -0.6%
For compound 4 the middle estimate is 1.6 percentage points above the measured one, within the range that was stated.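

Read in this assay, bromo in place of fluoro gave a number 0.1 percentage points lower from compound 3 to compound 4 (within the scatter), so the change did not carry its size over from the core of compound 1 to the core of compound 3: the same change on two cores in this assay, a number 24.9 percentage points lower (beyond the scatter) from compound 1 to compound 2 and a number 0.1 percentage points lower (within the scatter) from compound 3 to compound 4, 24.8 percentage points apart, beyond the scatter of two such steps The exchange of 4-methylpiperazin-1-yl for 1H-1,2,4-triazol-1-yl gave a number 71.4 percentage points lower from compound 2 to compound 4 (beyond the scatter), a large lowering on both the fluoro and the bromo pair, the same direction but not the same size: the same change on two cores in this assay, a number 96.2 percentage points lower (beyond the scatter) from compound 1 to compound 3 and a number 71.4 percentage points lower (beyond the scatter) from compound 2 to compound 4, 24.8 percentage points apart, beyond the scatter of two such steps This does not show that the halogen is without effect on the triazolyl core in general, since compound 3 at -0.5% and compound 4 at -0.6% both stand at essentially no inhibition, where a lowering has little room to appear, and the two gaps come from the same four compounds and so count as one result rather than two.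

From the compounds shown here alone, whether a chloro or a methoxy group at the same place would follow the step seen on the core of compound 1 stays open. Also open, going by these compounds, is how much inhibition remains with another amine, such as morpholine or piperidine, in place of 4-methylpiperazin-1-yl, and whether bromo in place of fluoro lowers the number on such a core.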